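A few compounds are considered here, and "the series" means these few. Any claim that something is new, unique, unknown or untested is made for them only; others in the source may bear on it.

Measured in a functional assay on HEK293 cells for agonist activity at Glucose-dependent insulinotropic receptor (Homo sapiens), read by cAMP accumulation, with a stated time of 30 min; a higher number here means that more compound is needed for the effect, a lower number that less compound is needed:
compound 1 `O=C1c2cc(C3CC3)nc(Oc3cccc(NS(=O)(=O)c4ccc(Cl)cc4)c3)c2C(=O)N1C1CC1` gives 45 nM
compound 2 `Cc1cc2c(c(Oc3cccc(NS(=O)(=O)c4ccc(Cl)cc4)c3)n1)C(=O)N(C)C2=O` gives 23 nM
compound 3 `Cc1cc2c(c(Oc3cccc(NS(=O)(=O)c4ccc(Cl)cc4)c3)n1)C(=O)N(C(C)C)C2=O` gives 13 nM

Compound 2 stands second highest of the three numbers; its gap to compound 3 and its gap to compound 1 both lie within the scatter, so no order among the three can be stated. Compound 4 `Cc1cc2c(c(Oc3cccc(NS(=O)(=O)c4ccc(Cl)cc4)c3)n1)C(=O)N(c1ccccc1)C2=O` differs from compound 2 by phenyl in place of methyl on an amide-type nitrogen in a ring. Among the compounds with values here, the only measured step at this position is a 1.8-fold lower number from compound 2 to compound 3 (0.25 log units; within the scatter), a change that stays within the scatter. Within the data shown here, no measured pair shows how a phenyl on that nitrogen behaves, so only a step of no more than the scatter is anticipated in this assay, with a wide range. Compound 4 is expected at 25 nM in this assay, between 8 nM and 80 nM. This estimate means an expected step of a 1.1-fold higher number from compound 2 to compound 4 (0.04 log units; within the scatter).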

Compound 4, half-maximal effective concentration: 299 nM
Estimate against measurement, compound 4: 12-fold (1.08 log units) below, and the stated range ends below it.
By their numbers in this assay, from the lowest: compounds 3, 2 and 1 (each within the scatter of the next, the first and the last beyond it); then compound 4.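

The amide-type nitrogen in the ring does not accept every group: phenyl in place of methyl gives a 13-fold higher number from compound 2 to compound 4 (1.11 log units; beyond the scatter), and phenyl in place of isopropyl gives a 23-fold higher number from compound 3 to compound 4 (1.36 log units; beyond the scatter). The earlier step from methyl to isopropyl stayed within the scatter, so only phenyl shows that this position can respond strongly to a change. Nothing measured here accounts for this result.

On these data alone, whether the rise follows the aromatic ring as such remains open. Cyclohexyl or benzyl on this nitrogen would bear on that question.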